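The compounds below may be only part of what the source reports. "The series", "measured", "known", "first", "only" and "open" are said of these compounds alone.

In a functional assay on LOX IMVI cells (Homo sapiens) for cytotoxicity, read by MTT assay, with a stated time of 24 h (a higher number here means a weaker inhibitor, a lower number a stronger inhibitor), compound 1 `COc1cc(-c2nc(-c3ccccc3)[nH]c2-c2ccnc(NCCCNS(=O)(=O)c3ccc(Br)cc3)n2)ccc1Cl` gives 23700 nM, compound 2 `COc1cc(-c2nc(-c3ccccc3)[nH]c2-c2ccnc(NCCCNS(=O)(=O)c3ccc(F)cc3)n2)ccc1Cl` gives 4530 nM and compound 3 `COc1ccc(S(=O)(=O)NCCCNc2nccc(-c3[nH]c(-c4ccccc4)nc3-c3ccc(Cl)c(OC)c3)n2)cc1` gives 1800 nM, so compound 2 stands in the middle of the three. Compound 4 `O=S(=O)(NCCCNc1nccc(-c2[nH]c(-c3ccccc3)nc2-c2ccc(Cl)c(O)c2)n1)c1ccc(F)cc1` differs from compound 2 by one change hydrogen in place of methyl on an oxygen on an aromatic ring, which turns methoxy to hydroxy. For the measured compounds named here, no measured step covers this change. The measured steps swap a different group, yet they show that single swaps can matter: modest for a 5.2-fold lower number from compound 1 to compound 2 (0.72 log units; beyond the scatter) and a 2.5-fold lower number from compound 2 to compound 3 (0.40 log units; beyond the scatter), large for a 13-fold lower number from compound 1 to compound 3 (1.12 log units; beyond the scatter). They give no direction here, so no step beyond the scatter is expected. The expected result is a 1.1-fold lower number from compound 2 to compound 4 (0.05 log units; within the scatter). Compound 4 is estimated at 4000 nM, with an expected range from 1300 nM to 12000 nM.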

Compound 4, half-maximal inhibitory concentration: 2300 nM
Compound 4: middle estimate off by 1.7-fold (0.24 log units), on the high side; the range from low to high includes it.
By their numbers in this assay, from the lowest: compounds 3, 4 and 2 (each within the scatter of the next, the first and the last beyond it); then compound 1.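

In this assay, replacing methoxy with hydroxy gives a 2.0-fold lower number from compound 2 to compound 4 (0.29 log units; within the scatter). For the compounds shown here, this is the first look at this oxygen, since the earlier steps all swapped a different group, and here losing the methyl leaves the result within the scatter. Nothing measured here offers an explanation for this result.

As far as these compounds go, whether an ethoxy group or an amine at this place would also leave the number unmoved stays open. So does whether hydroxy behaves the same alongside the bromo of compound 1 or the methoxy of compound 3 in place of the fluoro.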